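The compounds below may be only part of what the source reports. "The series", "measured", "known", "first", "only" and "open" are said of these compounds alone.

Measured so far in an ADME assay on a cell-free system (plasma, Rattus norvegicus) for metabolic stability, read by LC-MS, with a stated time of 1 h, at 37 degrees C, tested at 100 uM (on this read-out higher numbers stand for a more stable compound and lower numbers for a less stable compound), for three compounds:

Compound 1 `Cn1sc2cc(OCc3cccc(-c4ccc(Cl)c(C(=O)O)c4)c3)ccc2c1=O` gives 100%
Compound 2 `O=C(O)c1cc(F)cc(-c2cccc(COc3ccc4c(c3)CN(C3CCCC3)C4=O)c2)c1` gives 95%
Compound 3 `O=C(O)c1cc(-c2cccc(COc3ccc4c(=O)n(C5CCCC5)sc4c3)c2)cc([N+](=O)[O-])c1` gives 100%

Compound 1 stands level with compound 3, and compound 2 lies within the usual scatter of both, so these three cannot be ranked. Compound 4 `O=C(O)c1cc(-c2cccc(COc3ccc4c(=O)n(C5CC5)sc4c3)c2)ccc1Cl` is the core of compound 1 with cyclopropyl in place of methyl on an aromatic nitrogen and is still to be measured. Compound 4 is expected to stay within the scatter of compound 1 in this assay because compound 3 also has a carbon ring on that nitrogen and gives 100% in this test. The estimated step is a number 3 percentage points lower from compound 1 to compound 4 (within the scatter) and so stays within the scatter. Compound 4 is estimated at 97% with a range of 85% to 100% as the expected span.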

Compound 4, percent of the compound remaining: 100%
Estimate against measurement, compound 4: 3 percentage points below; low and high end bracket the measured number.
By their numbers in this assay, from the lowest: compounds 2, 1, 3 and 4 (each within the scatter of the next).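

In this assay, cyclopropyl in place of methyl on an aromatic nitrogen gives no change at the digits printed from compound 1 to compound 4 (within the scatter). For the compounds shown here, this pair differs in one place only, a comparison the earlier compounds did not offer, and it shows that this position accepts the small carbon ring here without a change beyond the scatter. Nothing available explains this result.

What the compounds shown leave open is how this position would respond to a longer chain or an amine. They also do not show whether the same change would hold on a different core.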